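The source may report more compounds than this note shows. Statements on the series, on what has been measured and on what is new or still open speak of the compounds shown alone.

Of the compounds shown here, three sharing one core have been measured in a functional assay on PC-12 cells (Rattus norvegicus) for cytotoxicity, read by MTT assay, with stated times of 2 h and 24 h, tested at 1 uM; a higher number here means a stronger effect of the compound at the concentration tested, a lower number a weaker effect. Compound 1 `Oc1cc(C(F)(F)F)ccc1-c1nc(-c2ccccc2O)n(-c2ccc(OC(F)(F)F)cc2)n1` gives 65.5%, compound 2 `Oc1cc(C(F)(F)F)ccc1-c1nc(-c2ccccc2O)n(-c2ccccc2F)n1` gives 63.4%, and compound 3 `Cc1ccc(-n2nc(-c3ccc(C(F)(F)F)cc3O)nc2-c2ccccc2O)c(C)c1` gives 73.7%. Compound 2 thus holds the lowest of the three numbers: the step of a number 2.1 percentage points lower from compound 1 to compound 2 (within the scatter) stays within the scatter, whereas the step of a number 10.3 percentage points higher from compound 2 to compound 3 (beyond the scatter) lies beyond it and counts as modest.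

Compound 4 `Oc1cc(C(F)(F)F)ccc1-c1nc(-c2ccccc2O)n(-c2cc(F)cc(F)c2)n1` has not yet been measured. It differs from compound 2 in one place: 3,5-difluorophenyl in place of 2-fluorophenyl on an aromatic nitrogen. The group on the aromatic nitrogen is also the only part that varies among compounds 1, 2 and 3, so all three measured steps bear on this change. The step of a number 8.2 percentage points higher from compound 1 to compound 3 (within the scatter) stays within the scatter. So does the step already named from compound 1 to compound 2, and only the step from compound 2 to compound 3 goes beyond it. Exchanges at this position have therefore moved this assay little, and compound 4 is expected to stay close to compound 2, with at most a small rise, which is what the expected step of a number 2.6 percentage points higher from compound 2 to compound 4 (within the scatter) expresses. Compound 4 is estimated at 66%, with a range from 56% to 76%.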

Compound 4, a percentage reported as activity, at one concentration (the size of the read-out at that concentration, not a potency): 75.5%
For compound 4 the middle estimate is 9.5 percentage points below the measured one, and the stated range covers the measured number.
By their numbers in this assay, from the lowest: compounds 2, 1, 3 and 4 (each within the scatter of the next, the first and the last beyond it).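

The change from 2-fluorophenyl to 3,5-difluorophenyl in this assay gives a number 12.1 percentage points higher from compound 2 to compound 4 (beyond the scatter), so a substituted phenyl that carries only fluorine on this aromatic nitrogen can also move the number beyond the scatter, as 2,4-dimethylphenyl did in compound 3. Against the other two groups the picture is flatter, with a number 1.8 percentage points higher from compound 3 to compound 4 (within the scatter) and a number 10 percentage points higher from compound 1 to compound 4 (within the scatter), so compound 4 cannot be separated from compound 3 or from compound 1, and only compound 2 lies beyond the scatter of both compound 3 and compound 4. The two steps that pass the scatter both start from compound 2, and compound 1, with its 4-(trifluoromethoxy)phenyl, stays within the scatter of every other compound, so the data show no simple order among these groups.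

Since 2-fluorophenyl and 3,5-difluorophenyl differ both in how many fluorine atoms they carry and in where these sit, this one step cannot tell the two differences apart, and nothing available explains the rise. As far as these compounds go, all four groups are phenyl rings bearing fluorine, methyl or trifluoromethoxy, so how this position responds to a phenyl bearing an amine or a carboxylic acid, or to a longer alkyl chain in place of the ring, remains open.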